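A hydroxy group added to the phenyl of compound 2

This account rests on a few compounds, and the source may have more. Where it says the series, first, only, none or still open, it means among the compounds named here.

Within the data shown here, in a functional assay on KB-VIN10 cells (Homo sapiens) for inhibition, with a stated time of 72 h (a higher number here means a weaker inhibitor, a lower number a stronger inhibitor), compound 2 `COc1ccc(S(=O)(=O)N2CCc3cccc(-c4ccccc4)c32)cc1` gives 107 nM, the higher of the two numbers so far. Compound 1 `COc1ccc(S(=O)(=O)N2CCc3cccc(-c4ccc(F)c(F)c4)c32)cc1`, which carries 3,4-difluorophenyl on the shared core, gives 46 nM. Compound 3 `COc1ccc(S(=O)(=O)N2CCc3cccc(-c4ccc(O)cc4)c32)cc1` keeps the core of compound 2 and differs in one place: hydroxy in place of hydrogen on an aromatic carbon. Hydroxy stands in place of hydrogen on an aromatic carbon, so phenyl becomes 4-hydroxyphenyl. Among the measured compounds shown here, only one measured step bears on this change, a 2.3-fold higher number from compound 1 to compound 2 (0.37 log units; beyond the scatter), and it is modest. For the measured compounds named here, that step concerns the same aryl group but involves fluorine rather than hydroxy, and no measured compound carries a hydroxy group. It therefore gives no firm direction, and no step beyond the scatter is expected in this assay. The expected change is a 1.1-fold higher number from compound 2 to compound 3 (0.05 log units; within the scatter). For compound 3 the estimated value is 120 nM, with an expected range of 40 nM to 350 nM.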

Compound 3, half-maximal inhibitory concentration: 123 nM
Beside the measured number, compound 3's estimate is 1.0-fold (0.01 log units) below it, and the stated range covers the measured number.
By their numbers in this assay, from the lowest: compound 1; then compounds 2 and 3 (each within the scatter of the next).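

In this assay, placing a hydroxy group on the aromatic carbon para to a large group gives a 1.1-fold higher number from compound 2 to compound 3 (0.06 log units; within the scatter), so the numbers for the phenyl and 4-hydroxyphenyl compounds cannot be told apart at this position. Set against the 3,4-difluorophenyl group, 4-hydroxyphenyl gives a 2.7-fold higher number from compound 1 to compound 3 (0.43 log units; beyond the scatter), which leaves compound 1 with the lowest number of the three, and its steps to compound 2 and compound 3 both lie beyond the scatter. Nothing available accounts for these numbers.

The compounds shown leave open whether an amine or a carboxylic acid on that same aromatic carbon would also stay within the scatter of compound 2. They also leave open whether a single fluorine on the phenyl would suffice to reach the number of compound 1.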